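Aryl ureas on a shared core at the alpha4/beta2 receptor

This account rests on a few compounds, and the source may have more. Where it says the series, first, only, none or still open, it means among the compounds named here.

Compound 1 `COc1ccc(NC(=O)N[C@@H]2C3CCN(CC3)[C@@H]2Cc2cccnc2)c(OC)c1`: > 10000 nM
Compound 2 `CSc1ccc(NC(=O)N[C@@H]2C3CCN(CC3)[C@@H]2Cc2cccnc2)cc1`: > 10000 nM
Compound 3 `O=C(Nc1cccc(C(F)(F)F)c1)N[C@@H]1C2CCN(CC2)[C@@H]1Cc1cccnc1`: > 10000 nM

Three aryl ureas built on a shared core were examined in an assay on a protein complex for binding affinity to Neuronal acetylcholine receptor; alpha4/beta2 (Homo sapiens); on this read-out higher numbers stand for weaker inhibition and lower numbers for stronger inhibition. For compound 2 the assay reports a limit only, > 10000 nM. Compound 1 likewise gives nothing more than a limit, > 10000 nM. Compound 3 also returns a limit, > 10000 nM. Compound 2 therefore stands exactly where the other two stand, at the limit of > 10000 nM in this assay, at which 3 of the 3 values shown sit, and no number separates it from them.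

Compound 4 `CN(C)c1ccc(NC(=O)N[C@@H]2C3CCN(CC3)[C@@H]2Cc2cccnc2)cc1` is the next member of the series. It differs from compound 2 by dimethylamino in place of methylsulfanyl on an aromatic carbon. Among the measured compounds shown here, no pair of measured compounds differing in one place is available to show how this assay responds to a change of that kind. The expectation rests on compound 2, whose result in this assay is the limit > 10000 nM. The step expected is a step that the limit leaves unreadable from compound 2 to compound 4, nothing beyond the scatter. Compound 4 is accordingly estimated at 15000 nM, in a range from 4000 nM to 60000 nM, most probably again reported as a limit.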

Compound 4, inhibition constant: > 10000 nM
Compound 4 gave a limit, no number (the forecaster's own chance of this, stated with the estimate: 85%); the middle value is on the limit's open side.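

Compound 2 and compound 4 both end at a limit in this assay, so no step can be read between them: the limit of > 10000 nM in this assay, at which 4 of the 4 values shown sit.

The compounds shown leave open whether any aryl group on the shared core would give a measurable value in this assay.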